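A few compounds are considered here, and "the series" means these few. Any claim that something is new, unique, unknown or untested is made for them only; others in the source may bear on it.

Measured in a functional assay on MCF7 cells (Homo sapiens) for cytotoxicity, read by MTT assay, with a stated time of 24 h; a higher number here means a weaker inhibitor, a lower number a stronger inhibitor:
- compound 1 `C=C1CC[C@H]2C(C)(C)CCC[C@]2(C)[C@H]1CCC(C)CC(=O)OC`: > 200000 nM, a limit
- compound 2 `Cc1ccc(/C=C2\CC[C@H]3C(C)(C)CCC[C@]3(C)[C@H]2CCC(C)CC(=O)O)cc1`: > 200000 nM, a limit

Among the compounds with values here, compound 2 has no number, only a limit, and the series so far offers only (the limit of > 200000 nM in this assay, at which 2 of the 2 values shown sit). Within the data shown here, no step between measured compounds is available to serve as a guide.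

Compound 3 `CC(CC[C@H]1/C(=C/c2ccc(I)cc2)CC[C@H]2C(C)(C)CCC[C@]12C)CC(=O)O` keeps the core of compound 2 and changes one substituent: iodo in place of methyl on an aromatic carbon. This is iodo in place of methyl on an aromatic carbon, para to a large group, or 4-methylphenyl to 4-iodophenyl.

The expectation rests on compound 2, whose > 200000 nM is a limit. A modest gain in inhibition is the expected direction, and another limit is somewhat more likely than a number. In this assay the expected change is an at least 1.3-fold lower number from compound 2 to compound 3 (0.12 log units; that floor lies within the scatter). For compound 3 the estimated value is 150000 nM, with an expected range of 50000 nM to 300000 nM.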

Compound 3, half-maximal inhibitory concentration: 89000 nM
Estimate against measurement, compound 3: 1.7-fold (0.23 log units) above; the measured number falls inside the stated range.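

In this assay the series now holds a measured number alongside its limits: the limit of > 200000 nM in this assay, at which 2 of the 3 values shown sit.

The aromatic carbon para to a large group is thus a place where a single substituent change can move the read-out: iodo in place of methyl gives an at least 2.2-fold lower number from compound 2 to compound 3 (0.35 log units; beyond the scatter). Compound 2 carries only a limit, so this step is a floor and not a size.

Open, from the compounds shown here alone, is whether the lower number is particular to iodo or would also appear with bromo, chloro or a methoxy group on the same carbon. The compounds shown also do not tell how an amine or a longer chain in place of the methyl or iodo would read, and no single-place step yet tests the acid side chain of compound 3.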